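A few compounds are considered here, and "the series" means these few. Any claim that something is new, unique, unknown or untested is made for them only; others in the source may bear on it.

Working notes on the series.

Of the compounds shown here, three on the shared core have been measured in an ADME assay on HEK293 cells for agonist activity at Toll-like receptor 8 (Homo sapiens), read by a luciferase reporter, with a stated time of 6 h; on this read-out lower numbers stand for an effect already at smaller amounts and higher numbers for an effect only at larger amounts of compound. Compound 1, `CCCCNc1nc(N)nc2cc(C(N)=O)ccc12`, gives 2 uM. Compound 2, `CCCCNc1nc(N)nc2ccc(CCc3ccc(N(C)C)cc3)cc12`, gives 0.5 uM. Compound 3, `CCCCNc1nc(N)nc2cccc(C)c12`, gives 0.3 uM, the lowest of the three numbers; its gap to compound 2 stays within the usual scatter of this assay, so no order between those two can be read, while its gap to compound 1 lies beyond the scatter.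

Compound 4, `CCCCNc1nc(N)nc2cccc(C(=O)N(C)C(C)C)c12`, is not yet measured. It differs from compound 3 in one place: isopropyl(methyl)carbamoyl in place of methyl on an aromatic carbon. For the measured compounds named here, no pair of measured compounds shows this kind of exchange, so the size of the step has no direct precedent here. Compound 1 carries a carboxamide group on a different aromatic carbon and gives the highest number of the three measured; compound 2 carries a large group and gives a number close to compound 3. On that basis the step of a 2.0-fold higher number from compound 3 to compound 4 (0.30 log units; within the scatter) is expected to be small, in the direction of a somewhat higher number, and is not expected to clear the scatter with confidence. The estimate for compound 4 in this assay is 0.6 uM, with a range from 0.15 uM to 2.5 uM.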

Compound 4, minimum effective concentration: > 25 uM
Compound 4 gave a limit, no number; the forecaster's own chance of this, stated with the estimate: 5%; middle value at least 41-fold (1.61 log units) away from the limit.
By their numbers in this assay, from the lowest: compounds 3 and 2 (each within the scatter of the next); then compound 1. At a limit, above all of these: compound 4.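

For compound 4 the read-out is a limit of the assay and not a number: the limit of > 25 uM in this assay, at which 1 of the 4 values shown sits. In this assay, for the compounds shown here, the exchange of methyl for isopropyl(methyl)carbamoyl gives an at least 83-fold higher number from compound 3 to compound 4 (1.92 log units; beyond the scatter), a large step beyond the scatter and the first step between compounds that differ in one place. Going by these compounds alone, this gives the first direct reading at this aromatic carbon, ortho to a fused ring and meta to a fused ring: the substituent here can decide the read-out on its own, with methyl giving a measured value and isopropyl(methyl)carbamoyl, at 7 heavy atoms against 1, giving only a limit.

The compounds shown leave open which part of the entering group goes with the step, since neither the unsubstituted carboxamide, the N-methyl carboxamide nor a plain isopropyl group appears at this carbon. They also leave open how an ethyl group, a hydroxymethyl group, an amine or a carboxylic acid would read here, and so whether the read-out falls away gradually or abruptly between methyl and isopropyl(methyl)carbamoyl.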